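This account rests on a few compounds, and the source may have more. Where it says the series, first, only, none or still open, it means among the compounds named here.

Of the compounds shown here, two sharing one core have been measured in a functional assay on HCC827 cells (Homo sapiens) for cytotoxicity, read by MTT assay, with a stated time of 72 h; on this read-out lower numbers stand for stronger inhibition and higher numbers for weaker inhibition. Compound 1 `c1ccc(Nc2ncc3nc(Nc4ccccc4)n(C4CCCC4)c3n2)cc1` gives 2.7 nM. Compound 2 `CN1CCN(c2ccc(Nc3ncc4nc(Nc5cccc([N+](=O)[O-])c5)n(C5CCCC5)c4n3)cc2)CC1` gives < 0.01 nM, which is a limit of the assay and not a number. This places compound 2 at the limit of < 0.01 nM in this assay, at which 1 of the 2 values shown sits.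

Compound 3 `C#Cc1cccc(Nc2nc3cnc(Nc4ccc(N5CCN(C)CC5)cc4)nc3n2C2CCCC2)c1` differs from compound 2 in one place, with ethynyl in place of nitro on an aromatic carbon, meta to a large group (ethynyl in place of nitro on an aromatic carbon). Within the data shown here, no measured pair shows this change on its own, so its size can only be expected. A moderate move towards weaker inhibition is expected in this assay, although a result that stays within the scatter would not be surprising. The expected change is an at least 5.0-fold higher number from compound 2 to compound 3 (0.69 log units; beyond the scatter). For compound 3 the estimated value is 0.05 nM, with an expected range of 0.01 nM to 0.8 nM.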

Compound 3, half-maximal inhibitory concentration: < 0.01 nM
Compound 3: no number, only a limit; the forecaster's own chance of this, stated with the estimate: 30%; middle value at least 5.0-fold (0.69 log units) from the limit.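

In this assay compound 3 gives < 0.01 nM, which is a limit of the assay and not a number. Among these compounds, compound 2 stands at the same limit, so no step between compound 2 and compound 3 can be read: the limit of < 0.01 nM in this assay, at which 2 of the 3 values shown sit. The compounds shown leave open whether ethynyl in place of nitro changes the value at all.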